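Pyridin-4-yl for 4-fluorophenyl in a growth-inhibition series

The compounds below may be only part of what the source reports. "The series", "measured", "known", "first", "only" and "open" are said of these compounds alone.

Measured compounds:
- compound 1 `CS(=O)(=O)c1ccc(-c2cnc3[nH]cc(-c4nnc(-c5ccc(Cl)cc5)o4)c(=O)c3c2)cc1`: 9.3%
- compound 2 `N#Cc1ccc(-c2cnc3[nH]cc(-c4nnc(-c5ccc(Cl)cc5)o4)c(=O)c3c2)cc1`: 9.73%
- compound 3 `CS(=O)(=O)c1ccc(-c2cnc3[nH]cc(-c4nnc(-c5ccc(F)cc5)o4)c(=O)c3c2)cc1`: 7.58%

In a functional assay on KB cells (Homo sapiens) for inhibition, read by MTT assay, with a stated time of 24 h, tested at 10 uM (a higher number here means more inhibition of growth at the concentration tested, a lower number less inhibition of growth), compound 1 gives 9.3%. Compound 2 differs from it by a cyano in place of methylsulfonyl on an aromatic carbon and gives 9.73%, a step of a number 0.4 percentage points higher from compound 1 to compound 2 (within the scatter). Compound 3 differs from compound 1 by a fluoro in place of chloro on an aromatic carbon. Compound 3 gives 7.58%, a step of a number 1.7 percentage points lower from compound 1 to compound 3 (within the scatter). All three numbers sit close together, and compound 3 is within the scatter of both companions; none of the three can be called more or less active than another.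

Compound 4 `CS(=O)(=O)c1ccc(-c2cnc3[nH]cc(-c4nnc(-c5ccncc5)o4)c(=O)c3c2)cc1` has not yet been measured. It differs from compound 3 as follows: pyridin-4-yl in place of 4-fluorophenyl on an aromatic carbon. Among the compounds with values here, no measured step exchanges one ring for another in this way; the two steps known, both within the scatter, only change a substituent on an aromatic ring. Given that compounds 1, 2 and 3 all lie within the scatter of each other, no step beyond the scatter is expected for compound 4, and a number 0.4 percentage points higher from compound 3 to compound 4 (within the scatter) is the estimate. The value expected for compound 4 is 8%, with a range from 0% to 20%.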

Compound 4, percent growth inhibition at one concentration: 3.02%
The estimate for compound 4 lay 5 percentage points above the measured number; the measured number falls inside the stated range.
By their numbers in this assay, from the lowest: compounds 4, 3, 1 and 2 (each within the scatter of the next).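

Within the data shown here, the pyridin-4-yl step is the first here to exchange a whole ring on the five-membered aromatic ring, rather than a substituent on a ring that stays in place. It brings a ring nitrogen and a hydrogen-bond acceptor to this position, and in this assay the exchange for 4-fluorophenyl gives a number 4.6 percentage points lower from compound 3 to compound 4 (within the scatter), while the exchange for 4-chlorophenyl gives a number 6.3 percentage points lower from compound 1 to compound 4 (within the scatter), so neither comparison separates the new ring from the old ones, even though these are the largest steps in the set. Among these compounds, no measurement on these compounds bears on what might lie behind the numbers.

From the compounds shown here alone, what remains open is whether any group at this position can move the number clear of the scatter, for example a phenyl ring carrying an amine or a carboxylic acid, or a longer chain in place of the ring. Going by these compounds, it is also open whether pyridin-4-yl would behave the same way with the cyano group of compound 2 on the other side of the shared core.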